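Fluoro on the sulfonylphenyl ring: compound 3 to compound 4

The source may hold more compounds than are shown below. What is called first, only, known or untested is meant among the compounds shown, and "the series" means these compounds.

Measured compounds:
compound 1 `CCc1cnc(N2CCC(n3ncc4c(C)c(-c5ccc(S(C)(=O)=O)cc5)ccc43)CC2)nc1` — 3420 nM
compound 2 `CCc1cnc(N2CCC(n3nnc4cc(-c5ccc(S(C)(=O)=O)cc5)ccc43)CC2)nc1` — 31 nM
compound 3 `CCc1cnc(N2CCC(n3nnc4cc(-c5ccc(S(C)(=O)=O)cc5)ncc43)CC2)nc1` — 21 nM

In a functional assay on HEK293 cells for agonist activity at Glucose-dependent insulinotropic receptor (Homo sapiens), read by HTRF and cAMP accumulation, with a stated time of 30 min (a lower number here means that less compound is needed, a higher number that more compound is needed for the effect), compound 1 gives 3420 nM, compound 2 gives 31 nM and compound 3 gives 21 nM. Compound 3 has the lowest number of the three, but its gap to compound 2 lies within the scatter, so the two cannot be ordered; only compound 1 stands clearly apart, beyond the scatter from both.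

Compound 4 `CCc1cnc(N2CCC(n3nnc4cc(-c5ccc(S(C)(=O)=O)cc5F)ncc43)CC2)nc1` differs from compound 3 in one place: fluoro in place of hydrogen on an aromatic carbon. Within the data shown here, no pair of measured compounds shows a step of this kind, so the expected size of the step in this assay rests on compound 3 alone. A single fluorine entering on an aromatic carbon, with no ring, donors or acceptors added, is expected to move the number little, with no direction beyond the scatter favoured.

For compound 4 the estimate in this assay is 18 nM, with a range from 6 nM to 55 nM. The expected step from compound 3 to compound 4 is a 1.2-fold lower number from compound 3 to compound 4 (0.07 log units; within the scatter), inside the scatter.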

Compound 4, half-maximal effective concentration in the Glucose-dependent insulinotropic receptor assay: 7 nM
Estimate against measurement, compound 4: 2.6-fold (0.41 log units) above, within the range that was stated.
By their numbers in the Glucose-dependent insulinotropic receptor assay, from the lowest: compound 4; then compounds 3 and 2 (each within the scatter of the next); then compound 1.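

Fluoro in place of hydrogen on an aromatic carbon, ortho to a large group and meta to a methylsulfonyl group, gives the first one-place step of the series, and in the Glucose-dependent insulinotropic receptor assay it reads a 3.0-fold lower number from compound 3 to compound 4 (0.48 log units; beyond the scatter), with compound 3 at 21 nM and compound 4 at 7 nM. In a physicochemical assay for solubility, read by HPLC, in phosphate buffer, measured as thermodynamic solubility, with a stated time of 24 h, at pH 6.8 (a higher number here means a more soluble compound, a lower number a less soluble compound), compound 3 gives 280 nM and the same change gives an at least 2.3-fold lower number from compound 3 to compound 4 (0.36 log units; beyond the scatter), so this position responds in both read-outs. In the physicochemical assay compound 4 gives < 120 nM, and that reading is a limit of the assay, not a number: the limit of < 120 nM in the physicochemical assay, at which 1 of the 2 values shown sits.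

As far as these compounds go, whether chloro or methoxy in place of the fluoro would hold the lower number in the Glucose-dependent insulinotropic receptor assay remains open. Also open, from the compounds shown here alone, are the actual solubility of compound 4 and whether an amine or a carboxylic acid on the 2-fluoro-4-(methylsulfonyl)phenyl group would raise the number in the physicochemical assay without losing the step in the Glucose-dependent insulinotropic receptor assay.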